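Adding a Nitro Group to Compound 3: Expected Bioavailability

The compounds below may be only part of what the source reports. "The series", "measured", "known", "first", "only" and "open" are said of these compounds alone.

Compound 3 `O=S(=O)(Nc1ccccc1)c1ccc2nc(-c3ccccc3)c(-c3ccccc3)nc2c1` is a sulfonamide built on a shared core, and in an ADME assay on the whole organism for pharmacokinetics, with Homo sapiens as the target (on this read-out higher numbers stand for higher oral bioavailability and lower numbers for lower oral bioavailability), compound 3 gives 100%. Among the compounds with values here, this puts compound 3 level with compound 1 `O=S(=O)(Nc1ccc2ccccc2c1)c1ccc2nc(-c3ccccc3)c(-c3ccccc3)nc2c1`, which in this assay gives 100%; together these two stand at the top of the three numbers known. Within the data shown here, the only lower value belongs to compound 2 `O=[N+]([O-])c1cccc(NS(=O)(=O)c2ccc3nc(-c4ccccc4)c(-c4ccccc4)nc3c2)c1`, which carries a 3-nitrophenyl group and in this assay gives 85.6%.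

Compound 4 `O=[N+]([O-])c1ccc(NS(=O)(=O)c2ccc3nc(-c4ccccc4)c(-c4ccccc4)nc3c2)cc1` is made from compound 3 by one change: nitro in place of hydrogen on an aromatic carbon. Read one bond further out, the phenyl becomes 4-nitrophenyl.

One measured step speaks directly to this. Removing a nitro group, a number 14.4 percentage points higher from compound 2 to compound 3 (beyond the scatter), so introducing one is the mirror image of that step. The difference between compound 1 and compound 3, no change at the digits printed from compound 1 to compound 3 (within the scatter), shows that the aryl group itself matters little here.

Adding the nitro group is therefore expected to lower the value by a modest amount, a number 13 percentage points lower from compound 3 to compound 4 (beyond the scatter). Compound 4 is estimated at 87%, within a range of 72% to 100%.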

Compound 4, oral bioavailability: 87.6%
Compound 4: the middle estimate sits 0.6 percentage points below what was measured, within the range that was stated.
By their numbers in this assay, from the lowest: compounds 2 and 4 (each within the scatter of the next); then compounds 1 and 3 (each within the scatter of the next).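

The new compound shows that the loss seen with the 3-nitrophenyl group is not tied to that one arrangement: in this assay, a nitro group para to a large group also brings a drop (a number 12.4 percentage points lower from compound 3 to compound 4 (beyond the scatter)), and the same gap appears against the larger aryl group (a number 12.4 percentage points lower from compound 1 to compound 4 (beyond the scatter)). Moving the nitro group from the 3-nitrophenyl to the 4-nitrophenyl arrangement makes no difference that can be told apart from the usual scatter (a number 2 percentage points higher from compound 2 to compound 4 (within the scatter)), so among these four compounds, the two that carry a nitro group both sit below the two that do not, and no compound goes against this. Nothing available here explains why the nitro group goes with the lower number.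

The compounds shown carry only nitro as an added group on the phenyl ring, so it remains open whether an amine or a carboxylic acid at the same place would bring a similar drop or none at all. From the compounds shown here alone, it also remains open whether a nitro group would have the same effect on the naphthalen-2-yl group of compound 1.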